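The compounds below may be only part of what the source reports. "The series", "measured", "known", "first", "only" and "open" are said of these compounds alone.

Of the compounds shown here, three sharing one core have been measured in a physicochemical assay for solubility, read by LC-MS, in phosphate buffer, with a stated time of 24 h, at pH 7.4; on this read-out lower numbers stand for lower solubility and higher numbers for higher solubility. Compound 1 `Cc1cc(-c2cnc(NCc3c(F)ccc4c3CCO4)c3cn[nH]c(=O)c23)n(C)n1` gives 1000 nM. Compound 2 `CNC(=O)c1ncc(-c2cnc(NCc3c(F)ccc4c3CCO4)c3cn[nH]c(=O)c23)n1C` gives 5000 nM, and compound 3 `Cn1nccc1-c1cnc(NCc2c(F)ccc3c2CCO3)c2cn[nH]c(=O)c12` gives 2000 nM. On these numbers compound 3 stands second highest of the three: its gap to compound 1 is within the scatter, while the step of a 2.5-fold lower number from compound 2 to compound 3 (0.40 log units; beyond the scatter) lies beyond it. Compound 4 `Cc1nn(C)cc1-c1cnc(NCc2c(F)ccc3c2CCO3)c2cn[nH]c(=O)c12` differs from compound 3 in one place: 1,3-dimethyl-1H-pyrazol-4-yl in place of 1-methyl-1H-pyrazol-5-yl on an aromatic carbon. Within the data shown here, no measured step makes exactly this change. The nearest guide is the step of a 2.0-fold higher number from compound 1 to compound 3 (0.30 log units; within the scatter), which removed a methyl from the 1,3-dimethyl-1H-pyrazol-5-yl group and stayed within the scatter. Compound 4 carries both methyls again, on a 1,3-dimethyl-1H-pyrazol-4-yl group, so a step of no more than the scatter is expected in this assay, with a slight lean toward a lower number. Compound 4 is therefore expected to reach about 1500 nM, between 600 nM and 4000 nM, which means an expected step of a 1.3-fold lower number from compound 3 to compound 4 (0.12 log units; within the scatter).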

Compound 4, solubility: 9000 nM
The estimate for compound 4 lay 6.0-fold (0.78 log units) below the measured number, and the stated range ends below it.
By their numbers in this assay, from the lowest: compounds 1 and 3 (each within the scatter of the next); then compounds 2 and 4 (each within the scatter of the next).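

Within this assay, placing the 1,3-dimethyl-1H-pyrazol-4-yl group on this aromatic carbon gives a 4.5-fold higher number from compound 3 to compound 4 (0.65 log units; beyond the scatter) and so moves the number far more than the earlier methyl step did. Compound 1 and compound 4 both carry a dimethylpyrazole and differ in how that ring is attached, and this alone gives a 9.0-fold higher number from compound 1 to compound 4 (0.95 log units; beyond the scatter) as the largest step in the set, so the point of attachment counts for more here than the methyl. Compound 4 also has no methylcarbamoyl group, yet the step of a 1.8-fold higher number from compound 2 to compound 4 (0.26 log units; within the scatter) leaves it indistinguishable from compound 2 within the scatter.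

Why the point of attachment matters so much stays open, as no supporting measurement bears on it. Also open, as far as these compounds go, is whether the number holds when an amine or a longer chain replaces a methyl on the 1,3-dimethyl-1H-pyrazol-4-yl group.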